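Swapping the amide aryl group: from compound 3 to compound 4

The compounds below may be only part of what the source reports. "The series", "measured", "known", "first", "only" and "open" are said of these compounds alone.

Measured compounds:
- compound 1, `Cc1cccc(Cl)c1NC(=O)CN1CCN(c2nnc(Cc3ccncc3)c3ccccc23)CC1`: 2670 nM
- compound 2, `O=C(CN1CCN(c2nnc(Cc3ccncc3)c3ccccc23)CC1)Nc1ccc(Br)cc1`: 19 nM
- compound 3, `O=C(CN1CCN(c2nnc(Cc3ccccc3)c3ccccc23)CC1)Nc1ccc(F)c(F)c1`: 2750 nM

In a functional assay on MDA-MB-231 cells (Homo sapiens) for cytotoxicity, read by MTT assay, with a stated time of 72 h (on this read-out higher numbers stand for weaker inhibition and lower numbers for stronger inhibition), compound 3 gives the highest of the three measured values; compound 1 sits at essentially the same level, within the scatter, while compound 2 lies far lower. The unmeasured compound 4, `Cc1ccccc1NC(=O)CN1CCN(c2nnc(Cc3ccccc3)c3ccccc23)CC1`, differs from compound 3 in one place: 2-methylphenyl in place of 3,4-difluorophenyl on an amide-type nitrogen. Going by the values given here, the only measured step that touches the group on the amide-type nitrogen is a 140-fold lower number from compound 1 to compound 2 (2.15 log units; beyond the scatter), where a 2-chloro-6-methylphenyl gave way to a 4-bromophenyl. Compound 1, carrying a 2-chloro-6-methylphenyl, and compound 3, carrying a 3,4-difluorophenyl, both sit at the weak end, and the 2-methylphenyl of compound 4 shares a methyl with the aryl of compound 1 rather than the bromine of compound 2. Among the compounds with values here, no measured pair shows the benzyl-for-pyridinylmethyl difference that also separates compounds 1 and 2 from compound 3, so that part is unknown. Compound 4 is therefore expected to stay near the weak level of compound 3, with a 1.1-fold higher number from compound 3 to compound 4 (0.04 log units; within the scatter), giving an estimate of 3000 nM within 700 nM to 13000 nM.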

Compound 4, half-maximal inhibitory concentration: 17300 nM
Estimate against measurement, compound 4: 5.8-fold (0.76 log units) below; measured number above the stated range.
By their numbers in this assay, from the lowest: compound 2; then compounds 1 and 3 (each within the scatter of the next); then compound 4.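

In this assay, the step of a 6.3-fold higher number from compound 3 to compound 4 (0.80 log units; beyond the scatter) shows that the aryl group on the amide-type nitrogen still changes the number when the other end of the molecule carries a benzyl group. The earlier step, a 140-fold lower number from compound 1 to compound 2 (2.15 log units; beyond the scatter), showed this only with a pyridinylmethyl group there. The new step also shows that compound 3 does not mark an upper limit for this series, since replacing 3,4-difluorophenyl with 2-methylphenyl raises the number further, though nothing measured here explains why.

From the compounds shown here alone, it remains open whether a 4-bromophenyl group would keep its low number alongside the benzyl group, and how much the change from pyridinylmethyl to benzyl matters alone. The effect of a cyclohexyl group or an aminophenyl group on the amide-type nitrogen is also unknown.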